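Anilino variation on the shared core: nitro to methyl

The source may report more compounds than this note shows. Statements on the series, on what has been measured and on what is new or still open speak of the compounds shown alone.

Measured so far in a functional assay on PC-3 cells (Homo sapiens) for inhibition, read by MTT assay, with a stated time of 72 h; on this read-out higher numbers stand for weaker inhibition and lower numbers for stronger inhibition:
- compound 1, `C=CC(=O)Nc1cccc(NC(=O)CSc2nc(Nc3ccccc3)c3ccccc3n2)c1`, gives 8740 nM
- compound 2, `C=CC(=O)Nc1cccc(NC(=O)CSc2nc(Nc3cccc(Br)c3)c3ccccc3n2)c1`, gives 15000 nM
- compound 3, `C=CC(=O)Nc1cccc(NC(=O)CSc2nc(Nc3cccc([N+](=O)[O-])c3)c3ccccc3n2)c1`, gives 46300 nM

Compound 3 stands at the highest number of the three in this assay, which on this read-out means the weakest inhibition. Both steps leading to it run in the same direction and lie beyond the scatter: a 5.3-fold higher number from compound 1 to compound 3 (0.72 log units; beyond the scatter) and a 3.1-fold higher number from compound 2 to compound 3 (0.49 log units; beyond the scatter). The step of a 1.7-fold higher number from compound 1 to compound 2 (0.23 log units; within the scatter) is within the scatter, so compound 1 and compound 2 cannot be ordered against each other.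

Compound 4, `C=CC(=O)Nc1cccc(NC(=O)CSc2nc(Nc3cccc(C)c3)c3ccccc3n2)c1`, is not yet measured. It differs from compound 3 in one place: methyl in place of nitro on an aromatic carbon. The measured steps that bear on this are the two that introduced the nitro group, from hydrogen and from bromo, each of them raising the number modestly. Methyl itself has no measured counterpart in the series, so the expectation rests only on removing the nitro. Because a 3.1-fold higher number from compound 2 to compound 3 (0.49 log units; beyond the scatter) and a 5.3-fold higher number from compound 1 to compound 3 (0.72 log units; beyond the scatter) both raised the number, taking the nitro away is expected to lower it again, toward the region of compound 1 and compound 2; the expected step is a 4.2-fold lower number from compound 3 to compound 4 (0.62 log units; beyond the scatter). For compound 4 the estimate in this assay is 11000 nM, with a range from 4000 nM to 30000 nM.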

Compound 4, half-maximal inhibitory concentration: 29200 nM
Compound 4: middle estimate off by 2.7-fold (0.42 log units), on the low side; measured number inside the range.
By their numbers in this assay, from the lowest: compounds 1, 2, 4 and 3 (each within the scatter of the next, the first and the last beyond it).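

Exchanging the nitro group for methyl on this aromatic carbon gives no readable change in this assay (a 1.6-fold lower number from compound 3 to compound 4 (0.20 log units; within the scatter)), so removing the nitro group alone does not bring the number back to that of compound 1. Methyl in place of hydrogen gives a step beyond the scatter (a 3.3-fold higher number from compound 1 to compound 4 (0.52 log units; beyond the scatter)), in the same direction as nitro in place of hydrogen, while methyl and bromo cannot be ordered (a 1.9-fold higher number from compound 2 to compound 4 (0.29 log units; within the scatter)); the higher number is therefore not peculiar to the nitro group, although compound 2 goes against any rule that every group here separates from hydrogen, since its step from compound 1 lies within the scatter. No measurement at hand gives a reason for these numbers.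

Still open, as far as these compounds go, is whether any group on this carbon gives a number clearly lower than that of compound 1, for example an amine, a hydroxyl or a methoxy group. Also open, from the compounds shown here alone, is whether a carboxylic acid or a longer alkyl chain here would fall with methyl and nitro or stay within the scatter of hydrogen.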